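Shortening the piperazine-bearing chain of compound 1

A few compounds are considered here, and "the series" means these few. Any claim that something is new, unique, unknown or untested is made for them only; others in the source may bear on it.

Measured so far in a functional assay on MDA-MB-231 cells (Homo sapiens) for cytotoxicity, read by MTT assay, with a stated time of 72 h; a higher number here means a weaker inhibitor, a lower number a stronger inhibitor:
compound 1 `CN1CCN(CCCCCn2c3c(c4ccccc42)C(=O)c2c[n+]([O-])c4ccccc4c2C3=O)CC1` gives 2270 nM
compound 2 `O=C1c2c[n+]([O-])c3ccccc3c2C(=O)c2c1c1ccccc1n2Cc1cn([C@H]2C[C@H](O)[C@@H](CO)O2)nn1` gives 580 nM
compound 3 `O=C1c2c[n+]([O-])c3ccccc3c2C(=O)c2c1c1ccccc1n2Cc1cn(CC(O)CO)nn1` gives 1290 nM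

Compound 1 has the highest number of the three; compound 3 is nearest, a 1.8-fold lower number from compound 1 to compound 3 (0.25 log units; within the scatter), while compound 2 lies furthest, its number lower than that of compound 1 by an amount beyond the scatter. Compound 4 `CN1CCN(CCCCn2c3c(c4ccccc42)C(=O)c2c[n+]([O-])c4ccccc4c2C3=O)CC1` differs from compound 1 only in the chain: 4-methylpiperazin-1-yl in place of (4-methylpiperazin-1-yl)methyl on a saturated chain carbon, four bonds along the chain from an aromatic nitrogen. Of the measured steps only one touches this part of the molecule, a 1.8-fold lower number from compound 1 to compound 3 (0.25 log units; within the scatter), and that swapped the whole substituent rather than trimming the chain; the step of a 2.2-fold higher number from compound 2 to compound 3 (0.35 log units; beyond the scatter) concerns a group on an aromatic nitrogen and gives no guide. Among the compounds with values here, no measured pair tests chain length alone, so for compound 4 the expected step is a 1.1-fold lower number from compound 1 to compound 4 (0.05 log units; within the scatter), none beyond the scatter. The estimate for compound 4 is 2000 nM, with a range from 1000 nM to 4500 nM.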

Compound 4, half-maximal inhibitory concentration: 110 nM
Estimate against measurement, compound 4: 18-fold (1.26 log units) above; measured number outside the range, below it.
By their numbers in this assay, from the lowest: compound 4; then compound 2; then compounds 3 and 1 (each within the scatter of the next).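

In this assay the chain length proves decisive: trimming 4-(4-methylpiperazin-1-yl)butyl to 3-(4-methylpiperazin-1-yl)propyl gives a 21-fold lower number from compound 1 to compound 4 (1.31 log units; beyond the scatter) even though the terminal group is unchanged. With the shorter chain, the swap against the triazole substituent also becomes large, with a 12-fold lower number from compound 3 to compound 4 (1.07 log units; beyond the scatter) in place of a step within the scatter for the longer chain. No evidence on hand accounts for this dependence on chain length.

On these data alone, whether 2-(4-methylpiperazin-1-yl)ethyl extends the trend or reverses it remains open. Also open, as far as these compounds go, is whether a morpholine on the same propyl chain would match the 4-methylpiperazin-1-yl group.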